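The source may hold more compounds than are shown below. What is called first, only, known or untested is meant among the compounds shown, and "the series" means these compounds.

Measured so far:
- compound 1, `CCOC(=O)[C@@H]1CC(=O)c2sccc2[C@H]1c1ccc(OC)cc1`: 15%
- compound 2, `CCOC(=O)[C@@H]1CC(=O)c2sccc2[C@H]1c1ccc(OCC)cc1`: 17.1%

Both values come from a physicochemical assay, read by spectrophotometry, with a stated time of 20 min, tested at 20 ug/mL; a higher number here means a stronger effect of the compound at the concentration tested, a lower number a weaker effect. Compound 1 and compound 2 lie within the scatter of each other, so on the two numbers shown compound 1 cannot be placed apart from compound 2; the one step measured, a number 2.1 percentage points higher from compound 1 to compound 2 (within the scatter), is within the scatter and is the only step in the set.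

The compound to be measured next is compound 3, `CCOC(=O)[C@@H]1CC(=O)c2sccc2[C@H]1c1ccc(OC)c(OC)c1`. Relative to compound 1 the change is methoxy in place of hydrogen on an aromatic carbon, placed on an aromatic carbon of a six-membered aromatic ring of carbon only, ortho to the methoxy group already present and meta to a large group.

For the measured compounds named here, the one measured step bears only loosely on this change: it alters the existing alkoxy chain rather than adding a group to the ring, and it stayed within the scatter. Going by the values given here, there is no measured step for a second methoxy on this ring. In this assay compound 3 is therefore expected to show no step beyond the scatter from compound 1, the expected step being a number 3 percentage points higher from compound 1 to compound 3 (within the scatter). The estimate for compound 3 is 18%, with a range of 8% to 30%.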

Compound 3, a percentage reported as activity, at one concentration (the size of the read-out at that concentration, not a potency): 14.7%
Compound 3: middle estimate off by 3.3 percentage points, on the high side; the range from low to high includes it.
By their numbers in this assay, from the lowest: compounds 3, 1 and 2 (each within the scatter of the next).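

In this assay, methoxy in place of hydrogen on an aromatic carbon, ortho to a methoxy group and meta to a large group, gives a number 0.3 percentage points lower from compound 1 to compound 3 (within the scatter), so this added group cannot be told apart from hydrogen at this position. The earlier pair covered only a change on the existing alkoxy chain, with a number 2.1 percentage points higher from compound 1 to compound 2 (within the scatter); the series now also holds a change made directly on the six-membered aromatic ring, and both single changes from compound 1 lie within the scatter. No separate measurement bears on the reason for this result.

The compounds shown leave open whether a hydroxyl group, an amine or a carboxylic acid at this position would give a read-out beyond the scatter from compound 1. They also leave open whether a longer chain in place of the methoxy group, or a carboxylic acid in place of the ethyl ester on the shared core, would separate from compound 1 in this assay.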